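The source may hold more compounds than are shown below. What is called first, only, known or untested is meant among the compounds shown, and "the series" means these compounds.

Compound 1 `COc1ccc(-c2cnc(NC(=O)c3ncc[nH]3)n2C)cc1`: > 100000 nM in a toxicity assay on THP-1 cells (Homo sapiens) for inhibition; a higher number here means that more compound is tolerated, a lower number that less compound is tolerated
Compound 2 `Cn1c(-c2ccc(Cl)cc2)cnc1NC(=O)c1ccc(F)cc1`: 37000 nM in this assay

In this assay compound 1 gives > 100000 nM, which is a limit of the assay and not a number, so compound 1 stands at the limit of > 100000 nM in this assay, at which 1 of the 2 values shown sits. Compound 2 gives 37000 nM in this assay. Compound 3 `COc1ccc(-c2cnc(NC(=O)c3cccc(O)c3)n2C)cc1` has not been measured; it differs from compound 1 in one place: 3-hydroxyphenyl in place of 1H-imidazol-2-yl on a carbonyl carbon. Within the data shown here, no step between measured compounds that differ in one place is available, so the size of this change is unknown. A step from compound 1 to compound 3 of an at least 1.1-fold lower number from compound 1 to compound 3 (0.04 log units; that floor lies within the scatter) is expected, within the scatter. Compound 3 is estimated at 90000 nM, with a range from 30000 nM to 200000 nM.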

Compound 3, half-maximal cytotoxic concentration: > 100000 nM
Compound 3: a limit, no number; the forecaster's own chance of this, stated with the estimate: 55%; middle value at least 1.1-fold (0.04 log units) from the limit.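

No step can be read from compound 1 to compound 3, since both stand at a limit of this assay and neither gives a number: the limit of > 100000 nM in this assay, at which 2 of the 3 values shown sit.

The compounds shown leave open whether 3-hydroxyphenyl in place of 1H-imidazol-2-yl on a carbonyl carbon changes how much compound is tolerated.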